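A few compounds are considered here, and "the series" means these few. Any claim that something is new, unique, unknown or untested is made for them only; others in the source may bear on it.

Measured so far in a functional assay on HBL-100 cells (Homo sapiens) for inhibition, read by sulforhodamine B assay, with a stated time of 48 h; on this read-out lower numbers stand for stronger inhibition of growth and higher numbers for weaker inhibition of growth:
compound 1, `O=C(CCCCCc1ccccc1)OCC1COCCOCCOCCOCCOCCO1` — 64000 nM
compound 2, `O=C(CCCCCCCCCCOc1ccccc1)OCC1COCCOCCOCCOCCOCCO1` — 20000 nM
compound 3, `O=C(CCCCC1CCCCC1)OCC1COCCOCCOCCO1` — > 100000 nM, a limit of the assay, not a number

Compound 1 stands highest of the two numbers given; compound 2 sits nearest, a 3.2-fold lower number from compound 1 to compound 2 (0.51 log units; beyond the scatter). Compound 3 is recorded only as the limit of > 100000 nM in this assay, at which 1 of the 3 values shown sits.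

Compound 4, `O=C(CCCc1cc2ccccc2[nH]1)OCC1COCCOCCOCCOCCOCCO1`, differs from compound 1 in one place: 1H-indol-2-yl in place of phenethyl on a saturated chain carbon, three bonds along the chain from a carbonyl carbon. Among the measured compounds shown here, no measured step covers this exchange; the only step, a 3.2-fold lower number from compound 1 to compound 2 (0.51 log units; beyond the scatter), alters the chain end in a different way and so gives no guidance on an aromatic ring with a hydrogen-bond donor in place of phenethyl. With nothing to point either way, the expected step is a 1.2-fold lower number from compound 1 to compound 4 (0.07 log units; within the scatter), none beyond the scatter. Compound 4 is therefore estimated at 55000 nM, with a range from 20000 nM to 150000 nM.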

Compound 4, concentration for 50% growth inhibition: > 100000 nM
Compound 4: no number, only a limit; the forecaster's own chance of this, stated with the estimate: 30%; middle value at least 1.8-fold (0.25 log units) away from the limit.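

Compound 4 gives only a limit in this assay, not a number, and such a limit is not unique to it: the limit of > 100000 nM in this assay, at which 2 of the 4 values shown sit.

Exchanging phenethyl for 1H-indol-2-yl on a saturated chain carbon, three bonds along the chain from a carbonyl carbon, gives an at least 1.5-fold higher number from compound 1 to compound 4 (0.19 log units; that floor lies within the scatter). At this position, the added five-membered aromatic ring with its hydrogen-bond donor brings no gain in growth inhibition.

From the compounds shown here alone, the true size of this step stays open, including whether it exceeds the scatter. Also open, going by these compounds, is whether an amine or a carboxylic acid on this chain, or a longer chain carrying 1H-indol-2-yl, would give a measurable number.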